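Swapping ethoxy for (methylsulfonyl)oxy on the shared core

The source may hold more compounds than are shown below. What is called first, only, known or untested is meant among the compounds shown, and "the series" means these compounds.

Compound 1 `CCOc1cc(-c2ccccc2)nc2ccccc12`: > 10 ug/mL (a limit of the assay)
Compound 2 `Oc1cc(-c2ccccc2)nc2ccc(Cl)cc12`: 0.7 ug/mL

In a functional assay on HCT-8 cells (Homo sapiens) for cytotoxicity (a lower number here means that less compound is needed, a higher number that more compound is needed for the effect), compound 1 gives > 10 ug/mL, which is a limit and not a number. Its place is thus (the limit of > 10 ug/mL in this assay, at which 1 of the 2 values shown sits). Compound 2 reads 0.7 ug/mL in this assay, a true number, but no comparison in a single place ties it to compound 1.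

Compound 3 `CS(=O)(=O)Oc1cc(-c2ccccc2)nc2ccccc12` has not yet been measured. It keeps the core of compound 1 and carries methylsulfonyl in place of ethyl on an oxygen on an aromatic ring. Among the measured compounds shown here, with no measured step to lean on, only a modest move in this assay toward less compound needed is expected, and a reading at the same limit remains quite possible. The expected step is an at least 1.2-fold lower number from compound 1 to compound 3 (0.09 log units; that floor lies within the scatter). For compound 3 the estimated value is 8 ug/mL, with an expected range of 1.5 ug/mL to 30 ug/mL.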

Compound 3, half-maximal effective concentration: 5.6 ug/mL
The estimate for compound 3 lay 1.4-fold (0.15 log units) above the measured number; measured number inside the range.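

At the oxygen on an aromatic ring, methylsulfonyl in place of ethyl gives a true number on the shared core in this assay: compound 3 reads 5.6 ug/mL. Compound 1 gives > 10 ug/mL, which is a limit of the assay. The change can be read only as a floor, an at least 1.7-fold lower number from compound 1 to compound 3 (0.25 log units; that floor lies within the scatter), and its full size stays unknown because one end of the step rests on a limit: the limit of > 10 ug/mL in this assay, at which 1 of the 3 values shown sits.

The compounds shown leave open whether a sulfonyl group is needed at this oxygen, or whether an acetyl group or a longer sulfonyl chain such as butylsulfonyl would read alike. Compound 2 differs from compound 3 in more than one place, so it does not settle what this change alone does.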